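The source may report more compounds than this note shows. Statements on the series, on what has been measured and on what is new or still open speak of the compounds shown alone.

Measured in a functional assay on U-251 cells (Homo sapiens) for antiproliferative activity, read by MTT assay, with a stated time of 24 h; on this read-out lower numbers stand for stronger inhibition and higher numbers for weaker inhibition:
- compound 1 `C=CCOc1ccc2c(=O)c(-c3cc(OC)c(OC)cc3OC)coc2c1`: 5900 nM
- compound 2 `COc1cc(OC)c(-c2coc3cc(OCc4ccccc4F)ccc3c2=O)cc1OC`: 2890 nM

Of these two, compound 2 has the lower number, 2890 nM, and so the stronger inhibition in this assay. Compound 3 `COc1cc(OC)c(-c2coc3cc(OCc4ccc([N+](=O)[O-])cc4)ccc3c2=O)cc1OC` keeps the shared core and changes one group, with 4-nitrophenyl in place of 2-fluorophenyl on a saturated chain carbon bound to an oxygen on an aromatic ring. Among the measured compounds shown here, only one measured step bears on this place, a 2.0-fold lower number from compound 1 to compound 2 (0.31 log units; beyond the scatter), and it is modest. That step replaces vinyl, so it does not show what an exchange of one substituted phenyl for another does. With no such exchange measured, no direction can be favoured, and no change beyond the scatter is expected. The estimated step is a 1.0-fold higher number from compound 2 to compound 3 (0.02 log units; within the scatter). Compound 3 is expected at 3000 nM, with an estimated range from 1200 nM to 7500 nM.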

Compound 3, half-maximal inhibitory concentration: 9400 nM
Estimate against measurement, compound 3: 3.1-fold (0.50 log units) below; the measured number lies above the stated range.
By their numbers in this assay, from the lowest: compound 2; then compounds 1 and 3 (each within the scatter of the next).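

In this assay, exchanging one substituted phenyl for another at this position is not neutral: 4-nitrophenyl in place of 2-fluorophenyl gives a 3.3-fold higher number from compound 2 to compound 3 (0.51 log units; beyond the scatter) and so takes the number back up. Set against the vinyl group, 4-nitrophenyl gives a 1.6-fold higher number from compound 1 to compound 3 (0.20 log units; within the scatter) and shows that a substituted phenyl on this chain carbon does not by itself lower the number, as the earlier step alone might have suggested. Nothing at hand accounts for the difference between the two phenyl groups.

The 2-fluorophenyl and 4-nitrophenyl groups differ both in the substituent and in its place on the ring, so the two effects remain unseparated. As far as these compounds go, how a 4-fluorophenyl, a 2-nitrophenyl or a plain phenyl group would read here remains open.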